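The source may report more compounds than this note shows. Statements on the series, on what has been measured and on what is new or still open speak of the compounds shown alone.

Compound 2 `Clc1cccc(-c2cc(-c3ccc(Cl)o3)cc(-c3cccs3)n2)c1` was tested in an assay on isolated protein for inhibition of DNA topoisomerase 1 (Homo sapiens), tested at 20 uM (a lower number here means a weaker effect, a higher number a stronger effect of the compound at the concentration tested), where compound 2 gives 8.5%. Among the two compounds measured, compound 2 has the highest number, but only in a narrow sense: the nearest compound is compound 1 `Clc1ccc(-c2cc(-c3cccs3)nc(-c3ccccc3Cl)c2)o1`, which in this assay gives 8%, and the step of a number 0.5 percentage points higher from compound 1 to compound 2 (within the scatter) lies within the scatter, so the two cannot be told apart.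

Compound 3 `Clc1ccc(-c2cc(-c3ccc(Cl)o3)cc(-c3cccs3)n2)cc1` is not yet measured. It differs from compound 2 in one place: 4-chlorophenyl in place of 3-chlorophenyl on an aromatic carbon.

Among the measured compounds shown here, the only step that bears on this change is the one from compound 1 to compound 2, in which a 3-chlorophenyl replaced a 2-chlorophenyl and a number 0.5 percentage points higher from compound 1 to compound 2 (within the scatter) changed nothing beyond the scatter. On that basis, a further shift to 4-chlorophenyl is expected to leave this assay unchanged beyond the scatter, so the step of no change at the digits printed from compound 2 to compound 3 (within the scatter) is estimated to be small. For compound 3 the expected value in this assay is 8.5%, with a range from 0% to 20%.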

Compound 3, a percentage reported as inhibition, at one concentration (the size of the read-out at that concentration, not a potency): 6.3%
Estimate against measurement, compound 3: 2.2 percentage points above, within the range that was stated.
By their numbers in this assay, from the lowest: compounds 3, 1 and 2 (each within the scatter of the next).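

The 4-chlorophenyl group on this aromatic carbon next to the ring nitrogen gives a number 2.2 percentage points lower from compound 2 to compound 3 (within the scatter) and a number 1.7 percentage points lower from compound 1 to compound 3 (within the scatter) in this assay and so stays level with both other chlorophenyl groups. All three chlorophenyl groups have now been compared at this position, so moving the chlorine around this phenyl ring makes no readable difference here, whereas the earlier step covered only two of them. Nothing measured here gives a reason for this result.

Still open, on these data alone, is whether this position responds to a different group, such as an amine or a carboxylic acid on the phenyl ring in place of the chlorine. As far as these compounds go, all three compounds also carry the same 5-chlorofuran-2-yl and thiophen-2-yl groups, so the effect of changing either one remains unknown.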